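Compound 3: fluoro in place of hydrogen, expected activity

The source may hold more compounds than are shown below. What is called first, only, known or untested is meant among the compounds shown, and "the series" means these compounds.

Measured so far:
compound 1 `Cn1c(=O)c(=O)n(C2CCCC2)c2nc(N/N=C/c3ccccc3)ncc21`: 48200 nM
compound 2 `Cn1c(=O)c(=O)n(C2CCCC2)c2nc(N/N=C/c3ccc(S(C)(=O)=O)cc3)ncc21`: 26600 nM

In a functional assay on PC-3 cells (Homo sapiens) for antiproliferative activity, read by MTT assay (on this read-out lower numbers stand for stronger inhibition and higher numbers for weaker inhibition), compound 1 gives 48200 nM, the higher of the two numbers shown; compound 2 gives 26600 nM, and the step of a 1.8-fold lower number from compound 1 to compound 2 (0.26 log units; within the scatter) is within the scatter. Compound 3 `Cn1c(=O)c(=O)n(C2CCCC2)c2nc(N/N=C/c3ccccc3F)ncc21` differs from compound 1 by fluoro in place of hydrogen on an aromatic carbon. Among the measured compounds shown here, the only measured step, methylsulfonyl in place of hydrogen on an aromatic carbon, a 1.8-fold lower number from compound 1 to compound 2 (0.26 log units; within the scatter), stayed within the scatter, and no step with fluoro exists in this set. A step of a 1.2-fold lower number from compound 1 to compound 3 (0.08 log units; within the scatter) is therefore expected, no change beyond the scatter. Compound 3 is estimated at 40000 nM, between 15000 nM and 100000 nM.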

Compound 3, half-maximal inhibitory concentration: 27600 nM
Compound 3: middle estimate off by 1.4-fold (0.16 log units), on the high side, within the range that was stated.
By their numbers in this assay, from the lowest: compounds 2, 3 and 1 (each within the scatter of the next).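

Fluoro on an aromatic carbon ortho to a large group gives a 1.7-fold lower number from compound 1 to compound 3 (0.24 log units; within the scatter), so a single fluorine at this place leaves compound 3 within the scatter of the unsubstituted compound 1. The step 2-fluorophenyl in place of 4-(methylsulfonyl)phenyl gives a 1.0-fold higher number from compound 2 to compound 3 (0.02 log units; within the scatter), so these two very different substituted phenyl groups cannot be told apart on this read-out. No available evidence bears on this result.

On these data alone, whether an amine or a carboxylic acid on the same aromatic carbon would move the number beyond the scatter stays open. So does the effect of fluoro on the other carbons of that phenyl.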